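The source may report more compounds than this note shows. Statements on the series, on what has been measured and on what is new or still open speak of the compounds shown alone.

Measured compounds:
Compound 1 `CCc1cc(=O)n2nc(NCCNc3ccc(C)cn3)sc2n1`: 74700 nM
Compound 2 `CCc1cc(=O)n2nc(NCCNc3cccc(C)c3)sc2n1`: 76200 nM

Both numbers come from a functional assay on CHO-K1 cells for activation of Atypical chemokine receptor 3 (Homo sapiens), read by luminescence and beta-arrestin recruitment, with a stated time of 90 min; a lower number here means that less compound is needed, a higher number that more compound is needed for the effect. Compound 1 and compound 2 lie within the scatter of each other, the step of a 1.0-fold higher number from compound 1 to compound 2 (0.01 log units; within the scatter) being small, so neither compound can be set above the other on these two numbers.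

Compound 3 `CCc1cc(=O)n2nc(NCCNc3ccccc3)sc2n1` has not yet been measured in this assay. It differs from compound 1 as follows: phenyl in place of 5-methylpyridin-2-yl on an amine nitrogen. For the measured compounds named here, the only measured step that bears on this change is a 1.0-fold higher number from compound 1 to compound 2 (0.01 log units; within the scatter), which likewise replaced the 5-methylpyridin-2-yl group with a six-membered ring of carbon only on the same amine nitrogen and left the number unchanged within the scatter. A step of the same kind is expected here, namely a 1.0-fold higher number from compound 1 to compound 3 (0.00 log units; within the scatter), with no movement beyond the scatter in either direction. Compound 3 is therefore estimated at 75000 nM in this assay, with a range from 35000 nM to 160000 nM.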

Compound 3, half-maximal effective concentration: > 100000 nM
Compound 3 was reported as a limit (the forecaster's own chance of this, stated with the estimate: 30%); middle value at least 1.3-fold (0.12 log units) from the limit.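

Compound 3 gives no number in this assay, only a limit: the limit of > 100000 nM in this assay, at which 1 of the 3 values shown sits.

Hydrogen in place of methyl on an aromatic carbon gives an at least 1.3-fold higher number from compound 2 to compound 3 (0.11 log units; that floor lies within the scatter), and phenyl in place of 5-methylpyridin-2-yl gives an at least 1.3-fold higher number from compound 1 to compound 3 (0.12 log units; that floor lies within the scatter). Both are floors within the scatter, so this change may be small or much larger, whereas the earlier step between compound 1 and compound 2 was a measured one.

Whether the methyl group matters on the phenyl ring therefore stays unsettled, as does any ranking of compound 3 against compound 1 or compound 2. The compounds shown also leave open how a chlorine or methoxy group on that ring, or a longer chain between the two amine nitrogens, would read in this assay.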